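Benzyl for propyl on the methylphenyl core: an expectation

This account rests on a few compounds, and the source may have more. Where it says the series, first, only, none or still open, it means among the compounds named here.

Compound 1 `CCCN1CC[C@@]2(OC)OC(N)=C(C#N)[C@@H](c3ccc(Cl)cc3)[C@@H]2C1`: 30300 nM
Compound 2 `CO[C@@]12CCN(Cc3ccccc3)C[C@H]1[C@H](c1ccc(Cl)cc1)C(C#N)=C(N)O2`: 18500 nM
Compound 3 `CCCN1CC[C@@]2(OC)OC(N)=C(C#N)[C@@H](c3ccc(C)cc3)[C@@H]2C1`: 21000 nM

Of the compounds shown here, three have been measured in a functional assay on trachea (Cavia porcellus); on this read-out lower numbers stand for stronger inhibition and higher numbers for weaker inhibition. Compound 1 gives 30300 nM, compound 2 gives 18500 nM, and compound 3 gives 21000 nM. The move from compound 1 to compound 2 is phenyl in place of ethyl on a saturated chain carbon bound to an amine nitrogen in a ring, and it produced a 1.6-fold lower number from compound 1 to compound 2 (0.21 log units; within the scatter). The core of compound 3 differs from that of compound 1 by methyl in place of chloro on an aromatic carbon, a move that produced a 1.4-fold lower number from compound 1 to compound 3 (0.16 log units; within the scatter).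

Compound 4 `CO[C@@]12CCN(Cc3ccccc3)C[C@H]1[C@H](c1ccc(C)cc1)C(C#N)=C(N)O2` has not yet been measured. It differs from compound 3 by phenyl in place of ethyl on a saturated chain carbon bound to an amine nitrogen in a ring, the same change as that between compound 1 and compound 2, at the same place. Among the measured compounds shown here, the earlier step of a 1.6-fold lower number from compound 1 to compound 2 (0.21 log units; within the scatter) gives the only guide, and a similar outcome is expected here. Compound 4 is therefore expected to show a step of a 1.6-fold lower number from compound 3 to compound 4 (0.21 log units; within the scatter) in this assay. The estimate for compound 4 is 13000 nM, with a likely range from 6000 nM to 30000 nM.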

Compound 4, half-maximal inhibitory concentration: 27100 nM
Compound 4: the middle estimate sits 2.1-fold (0.32 log units) below what was measured, and the stated range covers the measured number.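

In this assay, the change from propyl to benzyl gives a 1.3-fold higher number from compound 3 to compound 4 (0.11 log units; within the scatter), and methyl in place of chloro on an aromatic carbon gives a 1.5-fold higher number from compound 2 to compound 4 (0.17 log units; within the scatter). The change from propyl to benzyl does not differ measurably between the two cores: the same change on two cores in this assay, a 1.6-fold lower number (0.21 log units; within the scatter) from compound 1 to compound 2 and a 1.3-fold higher number (0.11 log units; within the scatter) from compound 3 to compound 4, 2.1-fold (0.33 log units) apart, within the scatter of two such steps. Among the compounds shown here, the same holds for methyl in place of chloro, but with every step this small, the data show no effect of either change that could be carried to another core, only that neither change produced a clear effect on these two: the same change on two cores in this assay, a 1.4-fold lower number (0.16 log units; within the scatter) from compound 1 to compound 3 and a 1.5-fold higher number (0.17 log units; within the scatter) from compound 2 to compound 4, 2.1-fold (0.33 log units) apart, within the scatter of two such steps.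

On these data alone, it remains open whether fluoro or methoxy on that aromatic carbon would shift the number beyond the scatter. The same question stands for a longer chain such as phenethyl on the amine nitrogen in the ring.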